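Dithioester enaminone series: bromophenyl analog, cell inhibition assay

A few compounds are considered here, and "the series" means these few. Any claim that something is new, unique, unknown or untested is made for them only; others in the source may bear on it.

compound 1 `CCCCSC(=S)C1=C(Nc2ccc(Cl)cc2Cl)CC(C)(C)CC1=O` gives > 100 ug/mL in a functional assay on cells (blood, Homo sapiens) for inhibition, read by chemiluminescence, with a stated time of 30 min (on this read-out lower numbers stand for stronger inhibition and higher numbers for weaker inhibition), a limit of the assay
compound 2 `CCCCSC(=S)C1=C(Nc2ccc(Cl)cc2)CC(C)(C)CC1=O` gives > 100 ug/mL in this assay, a limit
compound 3 `CC1(C)CC(=O)C=C(Nc2ccc(Br)cc2)C1` gives > 100 ug/mL in this assay, a limit

None of the three values is a number; compound 3 stands at the assay limit, as the limit of > 100 ug/mL in this assay, at which 3 of the 3 values shown sit, records for every value shown, and so it cannot be placed relative to the others. Among the compounds with values here, the only computable step, a step that the two limits leave unreadable from compound 1 to compound 2, is unreadable for the same reason. Compound 4 `CCCCSC(=S)C1=C(Nc2ccc(Br)cc2)CC(C)(C)CC1=O` introduces (a group of 7 heavy atoms (5 carbon, 2 sulfur; no ring) in place of a hydrogen atom, on a double-bonded ring carbon). Compound 2 carries that same group and also returns only a limit. Within the data shown here, no measured step informs the change, so the expected step that the limit leaves unreadable from compound 3 to compound 4 is none beyond the scatter. For compound 4 in this assay the estimate is 150 ug/mL, ranging from 40 ug/mL to 600 ug/mL, most probably reported again as a limit.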

Compound 4, half-maximal inhibitory concentration: > 100 ug/mL
Compound 4: only a limit was reported (the forecaster's own chance of this, stated with the estimate: 80%); the middle value does not contradict the limit.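

No step from compound 1, compound 2 or compound 3 to compound 4 can be read, as all four share one limit: the limit of > 100 ug/mL in this assay, at which 4 of the 4 values shown sit.

As far as these compounds go, whether any change on the shared core gives a measurable inhibition in this assay remains open.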